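A few compounds are considered here, and "the series" means these few. Any claim that something is new, unique, unknown or untested is made for them only; others in the source may bear on it.

Measured compounds and their values:
compound 1, `CC(=O)c1cccc(NC2=NCCC3(CCCCC3)S2)c1`, 74.7 10^-6 cm/s
compound 2, `Brc1ccc(NC2=NCCC3(CCCCC3)S2)cc1`, 90.3 10^-6 cm/s
compound 3, `c1ccc(NC2=NCCC3(CCCCC3)S2)cc1`, 1.81 10^-6 cm/s

In a physicochemical assay for permeability (a higher number here means that the compound crosses the layer faster, a lower number that the compound crosses the layer more slowly), compound 3 stands lowest of the three measured compounds; compound 1 lies nearest to it and compound 2 furthest, with both measured steps beyond the scatter: a 41-fold lower number from compound 1 to compound 3 (1.62 log units; beyond the scatter) and a 50-fold lower number from compound 2 to compound 3 (1.70 log units; beyond the scatter). Compound 4, `NC1=NCCC2(CCCCC2)S1`, has not been measured. It differs from compound 3 in one place: hydrogen in place of phenyl on an amine nitrogen.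

Neither measured step bears directly on this change. Both describe hydrogen in place of a substituent on an aromatic carbon of the phenyl, and both were large drops in this assay, while the step to compound 4 removes the phenyl itself from the amine nitrogen. Within the data shown here, no measured pair shows the consequence of that removal, so the expectation rests only on the fact that compound 3 already gives the lowest number of the set. Compound 4 is therefore expected to show no step beyond the scatter, a 1.5-fold lower number from compound 3 to compound 4 (0.18 log units; within the scatter), with a wide range around it. The estimate for compound 4 in this assay is 1.2 10^-6 cm/s, from 0.3 10^-6 cm/s to 5 10^-6 cm/s.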

Compound 4, apparent permeability: 7.33 10^-6 cm/s
For compound 4 the middle estimate is 6.1-fold (0.79 log units) below the measured one; the measured number lies above the stated range.
By their numbers in this assay, from the lowest: compound 3; then compound 4; then compounds 1 and 2 (each within the scatter of the next).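

In this assay, taking the phenyl off the amine nitrogen is itself a step beyond the scatter (a 4.0-fold higher number from compound 3 to compound 4 (0.61 log units; beyond the scatter)), so compound 3 with its bare phenyl stands lower than compound 4 with only hydrogen at this place. The earlier steps shown here touched only substituents on the aromatic carbons of that phenyl (a 41-fold lower number from compound 1 to compound 3 (1.62 log units; beyond the scatter); a 50-fold lower number from compound 2 to compound 3 (1.70 log units; beyond the scatter)), and both were large, whereas removing the whole phenyl gives a modest rise in the number. Nothing measured here offers an explanation for this step.

As far as these compounds go, whether a methyl, a benzyl or an acetyl on that amine nitrogen would fall nearer compound 3 or compound 4 remains open. Also open, from the compounds shown here alone, is whether a phenyl carrying a methoxy or a chloro would rise as far as those carrying bromo or acetyl did.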